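The source may hold more compounds than are shown below. What is called first, only, known or untested is meant among the compounds shown, and "the series" means these compounds.

In a functional assay on A549 cells (Homo sapiens) for antiproliferative activity, read by MTT assay, with a stated time of 48 h (a higher number here means a weaker inhibitor, a lower number a stronger inhibitor), compound 1 `Cc1ccc2[nH]c(-c3cn(-c4ccccc4)nc3-c3ccc(F)cc3)nc2c1` gives 1440 nM. Compound 3 `Clc1ccc(-c2nn(-c3ccccc3)cc2-c2nc3cc(Br)ccc3[nH]2)cc1`, which carries a 4-chlorophenyl group, gives 2170 nM. Compound 2 `Cc1cc2nc(-c3cn(-c4ccccc4)nc3-c3ccc(F)cc3)[nH]c2cc1C` stands at > 50000 nM, which is a limit of the assay and not a number. Methyl in place of hydrogen on an aromatic carbon gave an at least 34-fold higher number from compound 1 to compound 2 (1.54 log units; beyond the scatter). Compound 4 `Cc1cc2nc(-c3cn(-c4ccccc4)nc3-c3ccc(Cl)cc3)[nH]c2cc1C` keeps those methyl groups of compound 2 but has chloro in place of fluoro on an aromatic carbon, para to a large group (chloro in place of fluoro on an aromatic carbon). For the measured compounds named here, no measured step makes this swap alone, so no step beyond the scatter is expected in this assay. The expected result is an at least 1.2-fold lower number from compound 2 to compound 4 (0.09 log units; that floor lies within the scatter). For compound 4 the estimate is 40000 nM, within an expected range of 6000 nM to 100000 nM.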

Compound 4, half-maximal inhibitory concentration: 17700 nM
Compound 4: middle estimate off by 2.3-fold (0.35 log units), on the high side; the measured number falls inside the stated range.
By their numbers in this assay, from the lowest: compounds 1 and 3 (each within the scatter of the next); then compound 4. At a limit, above all of these: compound 2.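

In this assay the change from 4-fluorophenyl to 4-chlorophenyl, with the methyl groups kept, gives an at least 2.8-fold lower number from compound 2 to compound 4 (0.45 log units; beyond the scatter) and so shows that the number responds to which halogen sits at this position, even with those methyl groups present. The step gives only a floor for the true difference, because compound 2 stands at a limit of the assay: the limit of > 50000 nM in this assay, at which 1 of the 4 values shown sits.

As far as these compounds go, whether a bromo group, a methoxy group or an amine at this position would lower the number further stays open. Also open, from the compounds shown here alone, is how large the same chloro for fluoro swap would be on the core of compound 1.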